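The compounds below may be only part of what the source reports. "The series", "measured", "known", "first", "only" and "open" are said of these compounds alone.

Measured so far in an ADME assay on MDCK cells (Canis lupus familiaris) for cytotoxicity, read by MTT assay, with a stated time of 24 h; a lower number here means that less compound is tolerated, a higher number that more compound is tolerated:

Compound 1 `Cc1cc(CNS(=O)(=O)c2ccc(Cl)cc2)c(C)o1` gives 55700 nM.
Compound 2 `Cc1cc(CNS(=O)(=O)c2ccc(Br)cc2)c(C)o1` gives 29600 nM.
Compound 3 `Cc1cc(CNS(=O)(=O)c2ccc(Cl)cc2)c(C)s1` gives 52900 nM.

Compound 1 and compound 2 share one core and differ by bromo in place of chloro on an aromatic carbon; this gives a 1.9-fold lower number from compound 1 to compound 2 (0.27 log units; within the scatter). Compound 3 carries another core, and the difference between the core of compound 1 and the core of compound 3 is not broken down here; the values of compound 1 and compound 3 lie close together in this assay.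

Compound 4 `Cc1cc(CNS(=O)(=O)c2ccc(Br)cc2)c(C)s1` is not yet measured. It differs from compound 3 by bromo in place of chloro on an aromatic carbon, the same change seen between compound 1 and compound 2, at the same place. The step is expected to be of similar size, a 1.8-fold lower number from compound 3 to compound 4 (0.25 log units; within the scatter), because the one measured case gave a 1.9-fold lower number from compound 1 to compound 2 (0.27 log units; within the scatter), which lies within the scatter. Compound 4 is therefore estimated at 30000 nM, likely between 13000 nM and 70000 nM.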

Compound 4, half-maximal cytotoxic concentration: 56400 nM
Compound 4: the middle estimate sits 1.9-fold (0.27 log units) below what was measured, within the range that was stated.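

In this assay bromo in place of chloro on an aromatic carbon gives a 1.1-fold higher number from compound 3 to compound 4 (0.03 log units; within the scatter) and this can be set beside the earlier step on the other core. The two steps show no difference that can be told apart from ordinary assay variation, so in this small set the change carries over from one core to the other: the same change on two cores in this assay, a 1.9-fold lower number (0.27 log units; within the scatter) from compound 1 to compound 2 and a 1.1-fold higher number (0.03 log units; within the scatter) from compound 3 to compound 4, 2.0-fold (0.30 log units) apart, within the scatter of two such steps
Within the data shown here, this rests on only two pairs, each with a step within the scatter, so it does not show that the change has a real effect in this assay or that it would behave the same way on any further core.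

The compounds shown leave open what a different kind of group in that place, such as an amine, a carboxylic acid or a nitrile, would do to the tolerated concentration. They also leave open whether any group there would move the number beyond the scatter.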